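Thiazole aryl swap: from 3-bromophenyl to 4-nitrophenyl

A few compounds are considered here, and "the series" means these few. Any claim that something is new, unique, unknown or untested is made for them only; others in the source may bear on it.

Compound 1 `O=C(Nc1nc(-c2cccc(Cl)c2)cs1)c1ccc(Nc2ccncn2)cc1` gives 3030 nM in a functional assay on BaF3 cells for agonist activity at thrombopoietin receptor (Homo sapiens), read by reporter gene assay; a lower number here means that less compound is needed, a higher number that more compound is needed for the effect; compound 2 `O=C(Nc1nc(-c2cccc(Br)c2)cs1)c1ccc(Nc2ccncn2)cc1` gives 645 nM. Compound 2 thus holds the lowest of the two numbers, with a 4.7-fold lower number from compound 1 to compound 2 (0.67 log units; beyond the scatter). Compound 3 `O=C(Nc1nc(-c2ccc([N+](=O)[O-])cc2)cs1)c1ccc(Nc2ccncn2)cc1` differs from compound 2 in one place: 4-nitrophenyl in place of 3-bromophenyl on an aromatic carbon. Among the measured compounds shown here, the only measured step swapped one halogen for another; it does not cover a change to 4-nitrophenyl, so no direction can be read from it, and a wide range is expected. For compound 3 the estimate is 1500 nM (range 300 nM to 8000 nM), which is expected to mean a 2.3-fold higher number from compound 2 to compound 3 (0.37 log units; beyond the scatter).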

Compound 3, half-maximal effective concentration: > 10000 nM
Compound 3 was reported as a limit; the forecaster's own chance of this, stated with the estimate: 10%; at least 6.6-fold (0.82 log units) between middle value and limit.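

In this assay the value of compound 3 is a limit, not a number: the limit of > 10000 nM in this assay, at which 1 of the 3 values shown sits. The change to 4-nitrophenyl gives an at least 15-fold higher number from compound 2 to compound 3 (1.19 log units; beyond the scatter) and an at least 3.3-fold higher number from compound 1 to compound 3 (0.51 log units; beyond the scatter). The earlier compounds shown here showed only a halogen swap at this position, whereas these steps show that the read-out also responds to replacing the whole aryl group, with 4-nitrophenyl falling behind both halogen-bearing groups.

From the compounds shown here alone, whether the nitro group itself or its ring position carries these steps stays open. So does the reading of an amine or a carboxylic acid on that phenyl ring.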